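This account rests on a few compounds, and the source may have more. Where it says the series, first, only, none or still open, it means among the compounds named here.

Compound 1 `CCOC(=O)c1c(C)coc1-c1ccc2c(CC)cccc2c1OC` and compound 2 `CCCOC(=O)c1c(C)coc1-c1ccc2c(CC)cccc2c1OC` differ by one change, (methyl in place of hydrogen on a saturated chain carbon, two bonds along the chain from an oxygen next to a carbonyl group). In a functional assay on A549 cells (Homo sapiens) for cytotoxicity, read by MTT assay, with a stated time of 72 h (on this read-out higher numbers stand for an effect only at larger amounts of compound and lower numbers for an effect already at smaller amounts), compound 1 gives 3.8 ug/mL. Compound 2 reaches only a limit of this assay, > 10 ug/mL. The change thus made an at least 2.6-fold higher number from compound 1 to compound 2 (0.42 log units; beyond the scatter), a step whose floor rests on (the limit of > 10 ug/mL in this assay, at which 1 of the 3 values shown sits). Compound 3 `CCc1cccc2c(OC)c(-c3occ(C)c3CO)ccc12` has a different core, differing from compound 1 by hydroxymethyl in place of ethoxycarbonyl on an aromatic carbon; in this assay compound 3 gives 9.6 ug/mL, and that change made a 2.5-fold higher number from compound 1 to compound 3 (0.40 log units; beyond the scatter). Between compound 2 and compound 3 the comparison gives an at least 1.0-fold lower number from compound 2 to compound 3 (0.01 log units; that floor lies within the scatter). Compound 4 `CCOc1c(-c2occ(C)c2CO)ccc2c(CC)cccc12` has not yet been measured. It differs from compound 3 by methyl in place of hydrogen on a saturated chain carbon bound to an oxygen on an aromatic ring, the same kind of change as that from compound 1 to compound 2, though the place differs: here a saturated chain carbon bound to an oxygen on an aromatic ring, there a saturated chain carbon two bonds along the chain from an oxygen next to a carbonyl group. Among the measured compounds shown here, for compound 4 the expected step is a 1.9-fold higher number from compound 3 to compound 4 (0.27 log units; within the scatter), resting on an at least 2.6-fold higher number from compound 1 to compound 2 (0.42 log units; beyond the scatter) as the only measured instance of this kind of change. Compound 4 is therefore estimated at 18 ug/mL, with a likely range from 7 ug/mL to 45 ug/mL.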

Compound 4, concentration for half-maximal effect: > 10 ug/mL
Compound 4: a limit, no number; the forecaster's own chance of this, stated with the estimate: 70%; the middle value does not contradict the limit.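

In this assay compound 4 gives > 10 ug/mL, which is a limit of the assay and not a number. The step can therefore be read only as an at least 1.0-fold higher number from compound 3 to compound 4 (0.01 log units; that floor lies within the scatter), so it shows that adding the methyl leaves the compound at the limit on this core, as it does for compound 2 on the other, but it does not show how large the step really is. Whether the change carries over from one core to the other with the same size therefore remains unsettled, and the two steps cannot be told apart: the same change on two cores in this assay, an at least 2.6-fold higher number (0.42 log units; beyond the scatter) from compound 1 to compound 2 and an at least 1.0-fold higher number (0.01 log units; that floor lies within the scatter) from compound 3 to compound 4; the limit leaves it open whether they differ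

The compounds shown leave open what a longer chain, such as propoxy in place of the ethoxy of compound 4, would give in this assay. They also leave open whether an amine or a carboxylic acid in place of the hydroxymethyl of compound 3 would give a readable number, since so far the picture stops at one ceiling: the limit of > 10 ug/mL in this assay, at which 2 of the 4 values shown sit.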